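Dichloropyridyl semicarbazides: cyclohexyl to phenyl on the shared core

The source may report more compounds than this note shows. Statements on the series, on what has been measured and on what is new or still open speak of the compounds shown alone.

Measured compounds:
- Compound 1 `Cn1nc(C(F)(F)F)c2c(-c3ccccc3)cc(NNC(=O)Nc3cc(Cl)nc(Cl)c3)nc21` — 940 nM
- Compound 2 `Cc1cc(NNC(=O)Nc2cc(Cl)nc(Cl)c2)nc2c1c(C)nn2C` — 11000 nM
- Compound 3 `Cc1nn(C)c2nc(NNC(=O)Nc3cc(Cl)nc(Cl)c3)cc(C3CCCCC3)c12` — 2010 nM

All three were tested in an assay on isolated protein for binding affinity to sphingosine 1-phosphate receptor 2 (Homo sapiens), read by surface plasmon resonance; a lower number here means tighter binding, a higher number weaker binding. Compound 3 gives 2010 nM, the second highest of the three numbers; compound 1 sits nearer, and compound 2 further away at the high end. The one single-point step in the set is a 5.5-fold lower number from compound 2 to compound 3 (0.74 log units; beyond the scatter), which is the only shown comparison that touches the same position on the core.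

Compound 4 `Cc1nn(C)c2nc(NNC(=O)Nc3cc(Cl)nc(Cl)c3)cc(-c3ccccc3)c12` is the next compound in line. It differs from compound 3 in one place: phenyl in place of cyclohexyl on an aromatic carbon.

Among the compounds with values here, no measured step compares phenyl with cyclohexyl at this position. Compound 1 carries phenyl at the same position, with a different group elsewhere on its core, and in this assay compound 1 gives 940 nM; compound 3 with cyclohexyl gives 2010 nM. The two values suggest that the phenyl compound is unlikely to be far from compound 3. Compound 4 is therefore expected to show a 1.5-fold lower number from compound 3 to compound 4 (0.19 log units; within the scatter), a small shift if any toward tighter binding. The estimated value for compound 4 in this assay is 1300 nM, with a range from 500 nM to 3500 nM.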

Compound 4, dissociation constant: 5320 nM
Compound 4: the middle estimate sits 4.1-fold (0.61 log units) below what was measured, outside the stated range (above it).
By their numbers in this assay, from the lowest: compound 1; then compound 3; then compound 4; then compound 2.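

In this assay the two six-carbon rings are not interchangeable at this aromatic carbon: phenyl in place of cyclohexyl gives a higher number (a 2.6-fold higher number from compound 3 to compound 4 (0.42 log units; beyond the scatter)). Phenyl in place of methyl still gives a lower number (a 2.1-fold lower number from compound 2 to compound 4 (0.32 log units; beyond the scatter)), and the earlier phenyl value on the core of compound 1 proves to depend on the trifluoromethyl group, as methyl in its place gives a higher number (a 5.7-fold higher number from compound 1 to compound 4 (0.75 log units; beyond the scatter)). No measurement available here explains the difference between the two rings.

Still open, on these data alone, is whether trifluoromethyl in place of methyl lowers the number by a similar step when cyclohexyl occupies this position. Also open, as far as these compounds go, is how a pyridyl ring, or a phenyl ring carrying an amine, would compare with cyclohexyl at this position.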